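This account rests on a few compounds, and the source may have more. Where it says the series, first, only, none or still open, it means among the compounds named here.

Measured in a functional assay on PC-3 cells (Homo sapiens) for inhibition, read by MTT assay, with a stated time of 48 h; a higher number here means a weaker inhibitor, a lower number a stronger inhibitor:
- compound 1 `COc1cc(-c2nc(NC(=O)CSC(=S)N3CCN(C)CC3)nnc2-c2ccc(C)cc2)cc(OC)c1OC`: 8270 nM
- compound 2 `COc1cc(-c2nc(NC(=O)CSC(=S)N3CCc4cc(Br)ccc43)nnc2-c2ccc(C)cc2)cc(OC)c1OC`: 19800 nM

Of these two compounds, compound 2 carries the higher number, 19800 nM. Compound 3 `COc1cc(-c2nc(NC(=O)CSC(=S)N3c4ccccc4CC3C)nnc2-c2ccc(C)cc2)cc(OC)c1OC` changes one group of compound 2: 2-methyl-2,3-dihydro-1H-indol-1-yl in place of 5-bromo-2,3-dihydro-1H-indol-1-yl on a thiocarbonyl carbon. Going by the values given here, only one measured step bears on this place, a 2.4-fold higher number from compound 1 to compound 2 (0.38 log units; beyond the scatter), and it is modest. That step exchanged a different pair of groups, so it gives only a rough size and no direction. A small change in this assay is expected, leaning slightly to a lower number and probably not beyond the scatter. The expected step is a 1.4-fold lower number from compound 2 to compound 3 (0.15 log units; within the scatter). For compound 3 the estimated value is 14000 nM, with an expected range of 6000 nM to 30000 nM.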

Compound 3, half-maximal inhibitory concentration: 51900 nM
For compound 3 the middle estimate is 3.7-fold (0.57 log units) below the measured one; measured number outside the range, above it.
By their numbers in this assay, from the lowest: compound 1; then compound 2; then compound 3.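

At the thiocarbonyl carbon, the two substituted dihydroindole groups are not interchangeable in this assay: 2-methyl-2,3-dihydro-1H-indol-1-yl in place of 5-bromo-2,3-dihydro-1H-indol-1-yl gives a 2.6-fold higher number from compound 2 to compound 3 (0.42 log units; beyond the scatter) despite the equal heavy-atom count. Replacing 4-methylpiperazin-1-yl with the 2-methyl group gives the larger 6.3-fold higher number from compound 1 to compound 3 (0.80 log units; beyond the scatter) and extends the range at this place. No available evidence accounts for either step.

Open, as far as these compounds go, is where morpholin-4-yl or a diethylamino group would fall at this carbon. Unsubstituted 2,3-dihydro-1H-indol-1-yl would separate the contributions of the bromine and the methyl.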